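The source may hold more compounds than are shown below. What is called first, only, known or untested is meant among the compounds shown, and "the series" means these compounds.

Working notes on the series. In a functional assay on MCF7 cells (Homo sapiens) for cytotoxicity (on this read-out lower numbers stand for stronger inhibition and higher numbers for weaker inhibition), compound 1 (`Nc1ccc(-c2nc3cc(O)ccc3s2)cc1Cl`) gives 60600 nM and compound 2 (`CC(=O)Nc1ccc(-c2nc3cc(O)ccc3s2)cc1Cl`) gives 31000 nM on the same read-out. Compound 4 (`CC(=O)Nc1ccc(-c2nc3cc(O)ccc3s2)cc1C`) differs from compound 2 by a single change (methyl in place of chloro on an aromatic carbon): methyl in place of chloro on an aromatic carbon. Among the measured compounds shown here, the only measured step (a 2.0-fold lower number from compound 1 to compound 2 (0.29 log units; within the scatter)) is a different change, acetyl in place of hydrogen on a nitrogen, and lies within the scatter. Compound 2 differs from compound 3 (`CC(=O)Nc1ccc(-c2nc3c(O)cccc3s2)cc1C`) in more than one place, yet compound 3, which carries the methyl, gives 33000 nM and stands within the scatter of compound 2. No step beyond the scatter is therefore expected in this assay for this change. The estimated step (a 1.0-fold higher number from compound 2 to compound 4 (0.01 log units; within the scatter)) is expected to stay within the scatter. Compound 4 is expected at 32000 nM with a range from 16000 nM to 65000 nM.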

Compound 4, half-maximal inhibitory concentration: 72500 nM
The estimate for compound 4 lay 2.3-fold (0.36 log units) below the measured number; measured number above the stated range.
By their numbers in this assay, from the lowest: compounds 2, 3, 1 and 4 (each within the scatter of the next, the first and the last beyond it).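

Among the compounds shown here, at this position, ortho to an acetamido group, the exchange of chloro for methyl gives the only step beyond the scatter: in this assay there is a 2.3-fold higher number from compound 2 to compound 4 (0.37 log units; beyond the scatter), a modest one. Compound 3, which also carries the methyl, gives 33000 nM, so a methyl here does not go with the higher number in every compound shown; compound 3 differs from compound 4 in where the hydroxyl sits on the core.

No measurement at hand accounts for the step. On these data alone, whether a fluoro, a methoxy or an amine at this position would read like chloro or like methyl remains open.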